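The source may report more compounds than this note shows. Statements on the series, on what has been measured and on what is new or still open speak of the compounds shown alone.

Measured so far:
compound 1 `COC1(Cc2cccc(Cl)c2)CCN(c2ccc(C(=O)NS(=O)(=O)c3ccc(N[C@H](CCN(C)C)CSc4ccccc4)c([N+](=O)[O-])c3)cc2)CC1` — 300 nM
compound 2 `CN(C)CC[C@H](CSc1ccccc1)Nc1ccc(S(=O)(=O)NC(=O)c2ccc(N3CCC(=Cc4ccccc4C(F)(F)F)CC3)cc2)cc1[N+](=O)[O-]` — 210 nM

In a functional assay (FL5.12 cells, Mus musculus) with Apoptosis regulator Bcl-2 (Homo sapiens) as the target (on this read-out higher numbers stand for an effect only at larger amounts of compound and lower numbers for an effect already at smaller amounts), compound 2 gives 210 nM. In this assay compound 1 gives 300 nM, and the two values lie within the usual scatter of each other, so no order can be read from them.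

Compound 3 `CN(C)CC[C@H](CSc1ccccc1)Nc1ccc(S(=O)(=O)NC(=O)c2ccc(N3CCC(=Cc4cccnc4)CC3)cc2)cc1[N+](=O)[O-]` has not been measured yet. It differs from compound 2 in one place: pyridin-3-yl in place of 2-(trifluoromethyl)phenyl on a double-bonded chain carbon bound to a double-bonded ring carbon. Among the compounds with values here, no step between measured compounds covers this kind of exchange, so nothing says how this assay responds to it. The shared core and the basic side chain are unchanged, and the pair measured so far shows that the group on the double-bonded chain carbon can be varied without a change beyond the scatter. A modest step is expected for compound 3, of a 1.5-fold higher number from compound 2 to compound 3 (0.18 log units; within the scatter), not clearly beyond the scatter in either direction. The estimate for compound 3 is therefore 320 nM, with a range of 120 nM to 850 nM.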

Compound 3, half-maximal effective concentration: 5300 nM
Compound 3: middle estimate off by 17-fold (1.22 log units), on the low side; measured number above the stated range.
By their numbers in this assay, from the lowest: compounds 2 and 1 (each within the scatter of the next); then compound 3.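

In this assay, pyridin-3-yl in place of 2-(trifluoromethyl)phenyl on a double-bonded chain carbon bound to a double-bonded ring carbon gives a 25-fold higher number from compound 2 to compound 3 (1.40 log units; beyond the scatter) with the rest of the structure unchanged. Within the data shown here, this is the first exchange made in one place only, and it shows that this position does not tolerate every aromatic ring: the step is large and beyond the scatter. No measurement at hand bears on what lies behind the step.

The exchange removes the trifluoromethyl group and brings in a ring nitrogen in a single move, and the compounds shown do not separate these two changes. Also open, on these data alone, is where a plain phenyl, or a pyridine ring carrying trifluoromethyl, would fall on this read-out relative to compound 2 and compound 3.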